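Changing the Amine Chain of Compound 2

This account rests on a few compounds, and the source may have more. Where it says the series, first, only, none or still open, it means among the compounds named here.

In a functional assay on HeLa cells (Homo sapiens) for antiproliferative activity, read by MTT assay, with a stated time of 48 h (on this read-out higher numbers stand for weaker inhibition and lower numbers for stronger inhibition), compound 1 `CCN(CC)CCCn1c(N)c(-c2nc3ccccc3[nH]2)c2nc(C#N)c(C#N)nc21` gives 3150 nM as a measured number. Compound 2 `CN(C)CCn1c(N)c(-c2nc3cc(Cl)ccc3[nH]2)c2nc(C#N)c(C#N)nc21` stands at > 50000 nM in this assay and this value is a limit, not a number. The next compound to be read is compound 3 `CCN(CC)CCCn1c(N)c(-c2nc3cc(Cl)ccc3[nH]2)c2nc(C#N)c(C#N)nc21` and its difference from compound 2 is (diethylamino)methyl in place of dimethylamino on a saturated chain carbon, two bonds along the chain from an aromatic nitrogen with (diethylamino)methyl in place of dimethylamino on a saturated chain carbon, two bonds along the chain from an aromatic nitrogen. Cut one bond further out, 2-(dimethylamino)ethyl gives way to 3-(diethylamino)propyl. Within the data shown here, no measured pair isolates this change, so its size has to be judged indirectly. The 3-(diethylamino)propyl chain is also carried by compound 1 at 3150 nM and that value is the reason for expecting a lower number for compound 3, meaning stronger inhibition, by a margin beyond the usual scatter. The expected change is an at least 12-fold lower number from compound 2 to compound 3 (1.09 log units; beyond the scatter) in the direction of stronger inhibition. For compound 3 the estimated value is 4000 nM with an expected range from 1000 nM to 20000 nM on this read-out.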

Compound 3, half-maximal inhibitory concentration: 24400 nM
For compound 3 the middle estimate is 6.1-fold (0.79 log units) below the measured one; the whole stated range lies below it.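

In this assay, among these compounds, the chloro compounds now give a first reading of the chain itself: 3-(diethylamino)propyl in place of 2-(dimethylamino)ethyl, a change on a saturated chain carbon, two bonds along the chain from an aromatic nitrogen, gives an at least 2.0-fold lower number from compound 2 to compound 3 (0.31 log units; beyond the scatter). With that chain held constant, chloro in place of hydrogen on an aromatic carbon gives a 7.7-fold higher number from compound 1 to compound 3 (0.89 log units; beyond the scatter), so the chain does not set the number alone and this substitution on the shared core also moves the read-out beyond the usual scatter. The chain step can be stated only as a bound because compound 2 carries a limit and not a number: the limit of > 50000 nM in this assay, at which 1 of the 3 values shown sits.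

Chain length and the alkyl groups on the amine change together in the one step shown, so a 3-(dimethylamino)propyl or a 2-(diethylamino)ethyl chain is what would tell their contributions apart. Going by these compounds, it also remains open whether a cyclic amine such as morpholine or piperidine at the end of the chain, or a fluoro or methoxy group in place of the chloro, would shift the number in the same direction.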